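Diyne alcohols: carboxymethyl ether of compound 2

The compounds below may be only part of what the source reports. "The series", "measured", "known", "first", "only" and "open" are said of these compounds alone.

Measured compounds in a functional assay on SK-MEL-2 cells (Homo sapiens) for cytotoxicity; a higher number here means that more compound is needed for the effect, a lower number that less compound is needed:
Compound 1, `C=CCCCCCCCC#CC#CCO`: 3.94 ug/mL
Compound 2, `CCCCCCCC#CC#CCO`: 4.45 ug/mL
Compound 3, `CCCCCCCC#CC#CC(O)CC(C)=O`: 1.4 ug/mL

Compound 2 stands at the highest of the three numbers. The gap to compound 1 is small, a 1.1-fold higher number from compound 1 to compound 2 (0.05 log units; within the scatter). The gap to compound 3 is larger, a 3.2-fold lower number from compound 2 to compound 3 (0.50 log units; beyond the scatter).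

Compound 4, `CCCCCCCC#CC#CCOCC(=O)O`, differs from compound 2 by carboxymethyl in place of hydrogen on an oxygen on a saturated carbon. Going by the values given here, of the measured steps, only the one from compound 2 to compound 3 touches the same region, and it gave a 3.2-fold lower number from compound 2 to compound 3 (0.50 log units; beyond the scatter). Among the compounds with values here, that step left the hydroxy in place, whereas here its hydrogen is replaced; no measured step does that. The expectation is therefore a step no larger than modest in this assay, leaning toward a higher number, a 1.3-fold higher number from compound 2 to compound 4 (0.13 log units; within the scatter). Compound 4 is estimated at 6 ug/mL, with a range of 2 ug/mL to 18 ug/mL.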

Compound 4, concentration for half-maximal effect: 7.97 ug/mL
Beside the measured number, compound 4's estimate is 1.3-fold (0.12 log units) below it; the measured number falls inside the stated range.
By their numbers in this assay, from the lowest: compound 3; then compounds 1, 2 and 4 (each within the scatter of the next, the first and the last beyond it).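

Replacing the hydrogen on the oxygen with carboxymethyl gives, in this assay, a 1.8-fold higher number from compound 2 to compound 4 (0.25 log units; within the scatter). This is the first change shown to the hydroxy itself, and a free hydroxy is not needed for a number in this range, at least with this one replacement. Nothing available explains the size of this step.

Open, as far as these compounds go, is whether a methyl ether or the methyl ester of the carboxylic acid would read the same at this oxygen. Also open, from the compounds shown here alone, is whether carboxymethyl on the hydroxy of compound 3 would behave likewise.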